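The compounds below may be only part of what the source reports. "The series", "measured", "known", "first", "only" and "open" are said of these compounds alone.

Compound 1 `Nc1ccccc1NC(=O)CCCNCC(=O)Nc1cc(Cl)ccc1Cl` stands at the high end of the three numbers in a functional assay on HCT-116 cells (Homo sapiens) for inhibition, read by MTT assay, with a stated time of 2 days (on this read-out higher numbers stand for weaker inhibition of growth and lower numbers for stronger inhibition of growth), giving 78000 nM. Compound 3 `Nc1ccccc1NC(=O)c1ccc(NCC(=O)Nc2ccc(Cl)cc2)cc1` gives 62500 nM, which lies within the scatter of compound 1, while compound 2 `Nc1ccccc1NC(=O)c1ccc(NCC(=O)Nc2ccc([N+](=O)[O-])cc2)cc1` gives 6500 nM, a gap beyond the scatter. Within the data shown here, the only measured step, a 9.6-fold higher number from compound 2 to compound 3 (0.98 log units; beyond the scatter), concerns a different change on a different core. Compound 4 `Nc1ccccc1NC(=O)CCCNCC(=O)Nc1ccccc1Cl` differs from compound 1 by hydrogen in place of chloro on an aromatic carbon. Among the measured compounds shown here, no measured step bears on this hydrogen in place of chloro, so no shift beyond the scatter is expected. Compound 4 is therefore expected to give 80000 nM, with a range from 30000 nM to 200000 nM. The expected step of a 1.0-fold higher number from compound 1 to compound 4 (0.01 log units; within the scatter) is estimated to be small.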

Compound 4, concentration for total growth inhibition: > 100000 nM
Compound 4 gave a limit, no number (the forecaster's own chance of this, stated with the estimate: 15%); middle value at least 1.2-fold (0.09 log units) away from the limit.
By their numbers in this assay, from the lowest: compound 2; then compounds 3 and 1 (each within the scatter of the next). At a limit, above all of these: compound 4.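

Going from 2,5-dichlorophenyl to 2-chlorophenyl gives an at least 1.2-fold higher number from compound 1 to compound 4 (0.10 log units; that floor lies within the scatter), so hydrogen in place of chloro at this position shows no gain in growth inhibition. Compound 4 stands only as a limit, not as a number: the limit of > 100000 nM in this assay, at which 1 of the 4 values shown sits. The true size of this step stays unread, and its floor alone does not separate the two compounds.

The compounds shown leave open how an amine or a methoxy group on this aromatic carbon would read in this assay. They also leave open whether the nitro group of compound 2 would give a lower number on the core of compound 1.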